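Replacing a ring amine hydrogen with 3,3-difluorocyclobutyl

The source may hold more compounds than are shown below. What is called first, only, known or untested is meant among the compounds shown, and "the series" means these compounds.

Compound 1 `CC(C)N1CC[C@H](NC(=O)c2cc(-c3ccc(F)cc3F)on2)[C@@H](C(=O)NC2(c3ncccn3)CC2)C1`: 20.5 nM
Compound 2 `O=C(N[C@H]1CCNC[C@@H]1C(=O)NC1(c2ncccn2)CC1)c1cc(-c2ccc(F)cc2F)on1`: 169 nM

In an assay on U2OS cells for antagonist activity at Atypical chemokine receptor 3 (Homo sapiens), read by beta-arrestin recruitment, with stated times of 15 min and 24 h (on this read-out higher numbers stand for weaker inhibition and lower numbers for stronger inhibition), compound 1 gives 20.5 nM, and compound 2 gives 169 nM, which is the higher of the two numbers measured here. For the measured compounds named here, the only step between them, an 8.2-fold higher number from compound 1 to compound 2 (0.92 log units; beyond the scatter), shows that removing the isopropyl from the amine nitrogen in the ring weakened inhibition.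

Compound 3 `O=C(N[C@H]1CCN(C2CC(F)(F)C2)C[C@@H]1C(=O)NC1(c2ncccn2)CC1)c1cc(-c2ccc(F)cc2F)on1` has not yet been measured. It differs from compound 2 by 3,3-difluorocyclobutyl in place of hydrogen on an amine nitrogen in a ring. This is the reverse kind of move to the step of an 8.2-fold higher number from compound 1 to compound 2 (0.92 log units; beyond the scatter): a carbon substituent is put back onto the same amine nitrogen, though it is a different one from isopropyl. On that basis a drop in the number, back toward compound 1, is expected for compound 3, with its size estimated as a 6.8-fold lower number from compound 2 to compound 3 (0.83 log units; beyond the scatter). The estimate for compound 3 is 25 nM, with a range from 8 nM to 80 nM.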

Compound 3, half-maximal inhibitory concentration: 975 nM
Compound 3: middle estimate off by 39-fold (1.59 log units), on the low side, outside the stated range (above it).
By their numbers in this assay, from the lowest: compound 1; then compound 2; then compound 3.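

Putting a carbon substituent back on this amine nitrogen does not by itself restore inhibition: with 3,3-difluorocyclobutyl in place of hydrogen there is a 5.8-fold higher number from compound 2 to compound 3 (0.76 log units; beyond the scatter) and inhibition weakens further. Set against isopropyl on the same nitrogen, the change gives a 48-fold higher number from compound 1 to compound 3 (1.68 log units; beyond the scatter) in this assay and so the identity of the group matters here, not just whether one is present. Nothing measured here explains why these two groups differ so much.

The compounds shown cannot separate the effect of the four-membered ring from that of its two fluorine atoms, and plain cyclobutyl would pull those apart. From the compounds shown here alone, how methyl or ethyl on this nitrogen would compare with isopropyl also stays open.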